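The source may report more compounds than this note shows. Statements on the series, on what has been measured and on what is new or still open speak of the compounds shown alone.

Measured compounds:
- compound 1 `Cc1nc2c3ccccc3ccc2c2nc3c(ccc4ccccc43)c(-c3cccc4ccccc34)c12` gives 12100 nM in a functional assay on AGS cells (Homo sapiens) for cytotoxicity, read by MTT assay, with a stated time of 48 h; on this read-out higher numbers stand for weaker inhibition and lower numbers for stronger inhibition
- compound 2 `Cc1nc2c3ccccc3ccc2c2nc3c(ccc4ccccc43)c(-c3cc([N+](=O)[O-])ccc3N)c12` gives 17800 nM in this assay

Compound 2 carries the higher of the two numbers seen so far in this assay; its nearest neighbour is compound 1, and a 1.5-fold higher number from compound 1 to compound 2 (0.17 log units; within the scatter), so the two compounds cannot be told apart on this read-out.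

Compound 3 `Cc1nc2c3ccccc3ccc2c2nc3c(ccc4ccccc43)c(-c3ccccc3Cl)c12` has not yet been measured. It differs from compound 2 in one place: 2-chlorophenyl in place of 2-amino-5-nitrophenyl on an aromatic carbon. Among the compounds with values here, the only measured step that touches the same position is the one from compound 1 to compound 2, which exchanged one aromatic substituent for another on that carbon; that step, a 1.5-fold higher number from compound 1 to compound 2 (0.17 log units; within the scatter), stayed inside the scatter. With nothing beyond that to go on, the exchange of 2-amino-5-nitrophenyl for 2-chlorophenyl is expected to give no step beyond the scatter in this assay, that is a 1.3-fold lower number from compound 2 to compound 3 (0.10 log units; within the scatter). Compound 3 is therefore estimated at 14000 nM, with a plausible range from 6000 nM to 35000 nM.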

Compound 3, half-maximal inhibitory concentration: 52500 nM
The estimate for compound 3 lay 3.8-fold (0.57 log units) below the measured number; the measured number lies above the stated range.
By their numbers in this assay, from the lowest: compounds 1 and 2 (each within the scatter of the next); then compound 3.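

In this assay, this aromatic carbon, opposite the ring nitrogen, proves sensitive to the group it carries: the exchange for 2-chlorophenyl gives a 2.9-fold higher number from compound 2 to compound 3 (0.47 log units; beyond the scatter) and, measured against naphthalen-1-yl, a 4.3-fold higher number from compound 1 to compound 3 (0.64 log units; beyond the scatter), whereas the earlier exchange gave only a 1.5-fold higher number from compound 1 to compound 2 (0.17 log units; within the scatter). Compound 3 is therefore the weakest of the three, and 2-chlorophenyl stands apart from two quite different groups, naphthalen-1-yl and 2-amino-5-nitrophenyl, which this read-out cannot tell apart. Nothing measured here accounts for why the change to 2-chlorophenyl moves the number.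

The compounds shown do not reveal whether the higher number goes with the chlorine itself or with the single carbon ring that carries it, a question that an unsubstituted phenyl, a 2-methoxyphenyl or a 2-fluorophenyl group at this carbon would bear on. They also leave open what the amino and nitro groups of 2-amino-5-nitrophenyl each contribute, since the two always appear together, and whether a 2-aminophenyl or a 3-nitrophenyl group would sit nearer compound 2 or compound 3.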